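Demethylation of the amine in allenyl benzylamine series

The source may hold more compounds than are shown below. What is called first, only, known or untested is meant among the compounds shown, and "the series" means these compounds.

Working notes on four compounds assessed in an assay on forebrain for inhibition of Monoamine oxidase (Mus musculus); a higher number here means that more compound is needed for the effect, a lower number that less compound is needed.

Among the measured compounds shown here, compound 2 `C=C=C(Cc1ccccc1)CN(C)C` is the only compound with a fully read value: in this assay compound 2 gives 72 umol/kg. Compound 3 `C=C=C(CNC)Cc1ccccc1` returns only a limit of the assay in this assay, namely > 38 umol/kg. Compound 1 `C=C=CCN(C)Cc1ccccc1` also returns only a limit of the assay in this assay, namely > 48 umol/kg. The difference between the core of compound 1 and the core of compound 2 is not broken down here.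

The change from compound 2 to compound 3 is hydrogen in place of methyl on an amine nitrogen. Its size is recorded as a step that the limit leaves unreadable from compound 2 to compound 3; the step cannot be read because the limit of > 38 umol/kg in this assay, at which 1 of the 3 values shown sits, sets the value of compound 3 as a limit rather than a number.

Compound 4 `C=C=CCNCc1ccccc1` has not yet been measured. It arises from compound 1 by hydrogen in place of methyl on an amine nitrogen, the same change as that between compound 2 and compound 3, since both place descriptions agree word for word. For the measured compounds named here, the single measured instance of this change gives no readable size, and compound 1 itself sits at a limit, (the limit of > 48 umol/kg in this assay, at which 1 of the 3 values shown sits), so there is little to carry over. On that basis compound 4 is expected to give 90 umol/kg in this assay, with a plausible range from 45 umol/kg to 200 umol/kg. The expected step is a step that the limit leaves unreadable from compound 1 to compound 4, with a high chance that the assay again reports only a limit.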

Compound 4, dose for half-maximal effect: > 51 umol/kg
Compound 4: a limit, no number (the forecaster's own chance of this, stated with the estimate: 70%); the middle value does not contradict the limit.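

Among the compounds shown here, compound 1 and compound 4 both return only a limit of the assay in this assay: the step between them, hydrogen in place of methyl on an amine nitrogen, cannot be read, and no new step follows. The compounds shown leave open how large this change is in either pair, compound 1 to compound 4 or compound 2 to compound 3, with compound 2 the only compound holding a fully read value.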